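Urea to benzamide at the pyrazole series

The source may report more compounds than this note shows. Statements on the series, on what has been measured and on what is new or still open speak of the compounds shown alone.

Compound 3 `COc1cc(-c2nn(-c3cccc(NC(=O)Nc4cccc(C(F)(F)F)c4)c3)cc2-c2ccncc2)ccc1Cl` gives 4040 nM in a functional assay on A498 cells (Homo sapiens) for inhibition, read by sulforhodamine B assay, with a stated time of 48 h (a lower number here means a stronger inhibitor of growth, a higher number a weaker inhibitor of growth), the highest of the two numbers shown. Compound 2 `COc1cc(-c2nn(-c3cccc(NC(=O)Nc4cc(C(F)(F)F)cc(C(F)(F)F)c4)c3)cc2-c2ccncc2)ccc1Cl` gives 1900 nM, so the step of a 2.1-fold higher number from compound 2 to compound 3 (0.33 log units; beyond the scatter) follows hydrogen in place of trifluoromethyl on an aromatic carbon. Compound 1 `O=C(Nc1cccc(-n2cc(-c3ccncc3)c(-c3ccc(Cl)c(O)c3)n2)c1)Nc1cccc(C(F)(F)F)c1` gives only a limit, > 32500 nM. The step of an at least 8.0-fold lower number from compound 1 to compound 3 (0.90 log units; beyond the scatter) is large. Compound 4 `COc1cc(-c2nn(-c3cccc(NC(=O)c4ccccc4)c3)cc2-c2ccncc2)ccc1Cl` carries the change (phenyl in place of (3-(trifluoromethyl)phenyl)amino on a carbonyl carbon). Among the compounds with values here, of the measured steps only that from compound 2 to compound 3 touches the same end of the molecule, and it was modest; here the whole (3-(trifluoromethyl)phenyl)amino is lost, so a larger rise is expected, a 3.0-fold higher number from compound 3 to compound 4 (0.47 log units; beyond the scatter). Compound 4 is therefore estimated at 12000 nM, with a range of 4000 nM to 35000 nM.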

Compound 4, concentration for total growth inhibition: 3140 nM
Estimate against measurement, compound 4: 3.8-fold (0.58 log units) above; measured number below the stated range.
By their numbers in this assay, from the lowest: compounds 2, 4 and 3 (each within the scatter of the next, the first and the last beyond it). At a limit, above all of these: compound 1.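

In this assay, phenyl in place of (3-(trifluoromethyl)phenyl)amino on the carbonyl carbon gives a 1.3-fold lower number from compound 3 to compound 4 (0.11 log units; within the scatter), so this end of the molecule tolerates losing the amino nitrogen with its hydrogen-bond donor and the trifluoromethyl group without a change beyond the scatter. The urea is therefore not needed to hold the number at this level in this pair. Nothing at hand gives a cause for this result.

Still open, as far as these compounds go, is whether trifluoromethyl on the benzamide phenyl would give a step like the one seen between the ureas. From the compounds shown here alone, the readings of an amine or a carboxylic acid on that ring, or of a longer chain on the carbonyl carbon, also remain open.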